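The source may report more compounds than this note shows. Statements on the series, on what has been measured and on what is new or still open speak of the compounds shown alone.

Measured in a functional assay on MT4 cells (Homo sapiens) for cytotoxicity, read by MTT assay; a higher number here means that more compound is tolerated, a lower number that less compound is tolerated:

- Compound 1 (`Cc1c(O)nc(SCc2ccccc2)nc1Cc1c(Cl)cccc1Cl`) gives > 64000 nM, which is a limit.
- Compound 2 (`Cc1c(O)nc(SCc2cccc(C#N)c2)nc1Cc1c(Cl)cccc1Cl`) gives > 60000 nM, which is a limit.

Compound 2 therefore has no exact number in this assay and stands only at a limit (the limit of > 60000 nM in this assay, at which 1 of the 2 values shown sits). Compound 3 (`Cc1c(O)nc(SCc2cccc(Cl)c2)nc1Cc1c(Cl)cccc1Cl`) has chloro in place of cyano on an aromatic carbon, meta to a large group (chloro in place of cyano on an aromatic carbon). Going by the values given here, the one measured step that bears on this change is a step that the two limits leave unreadable from compound 1 to compound 2, which puts cyano in place of hydrogen on an aromatic carbon. Its size cannot be read, so it gives no ground for expecting a shift in either direction, and no change beyond the scatter is expected in this assay. The expected step is small (an at least 1.0-fold lower number from compound 2 to compound 3 (0.03 log units; that floor lies within the scatter)). Compound 3 is estimated at 55000 nM, with an expected range from 22000 nM to 80000 nM, and it may well be reported as a limit again.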

Compound 3, half-maximal cytotoxic concentration: > 59000 nM
Compound 3: no number, only a limit; the forecaster's own chance of this, stated with the estimate: 65%; middle value at least 1.0-fold (0.03 log units) away from the limit.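

In this assay compound 3 gives > 59000 nM, which is a limit. Going by these compounds alone, compound 1, compound 2 and compound 3 all stand only at limits, so no step among them can be read. The compounds shown leave open at what concentration any of them becomes cytotoxic.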